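Aryl group variation on the shared core, working notes

The source may hold more compounds than are shown below. What is called first, only, known or untested is meant among the compounds shown, and "the series" means these compounds.

Measured so far in a functional assay on MCF7 cells (Homo sapiens) for inhibition, read by MTT assay, with a stated time of 72 h; a higher number here means a weaker inhibitor, a lower number a stronger inhibitor:
compound 1 `CC(C)c1ccc(-c2nc(SCc3cn(CC(=O)NC(=O)Nc4ccccn4)nn3)nc(Nc3cccc([N+](=O)[O-])c3)c2C#N)cc1` gives 25900 nM
compound 2 `CC(C)c1ccc(Nc2nc(SCc3cn(CC(=O)NC(=O)Nc4ccccn4)nn3)nc(-c3ccc(C(C)C)cc3)c2C#N)cc1` gives 28600 nM

Compound 2 stands highest of the two numbers in this assay; its nearest neighbour is compound 1, and the step from compound 1 to compound 2 is a 1.1-fold higher number from compound 1 to compound 2 (0.04 log units; within the scatter), within the scatter. Compound 3 `CC(C)c1ccc(Nc2nc(SCc3cn(CC(=O)NC(=O)Nc4ccccn4)nn3)nc(-c3ccc(Cl)cc3)c2C#N)cc1` is not yet measured; it differs from compound 2 by chloro in place of isopropyl on an aromatic carbon. For the measured compounds named here, no measured step bears directly on a change on an aromatic carbon of this ring; the only measured step concerns a group on a nitrogen and lay within the scatter. The expected step is therefore a 1.0-fold lower number from compound 2 to compound 3 (0.01 log units; within the scatter), none beyond the scatter. Compound 3 is estimated at 28000 nM, in the range 12000 nM to 70000 nM.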

Compound 3, half-maximal inhibitory concentration: 39900 nM
Compound 3: middle estimate off by 1.4-fold (0.15 log units), on the low side, and the stated range covers the measured number.
By their numbers in this assay, from the lowest: compounds 1, 2 and 3 (each within the scatter of the next).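

In this assay, the change from 4-isopropylphenyl to 4-chlorophenyl, on an aromatic carbon para to a large group, gives a 1.4-fold higher number from compound 2 to compound 3 (0.14 log units; within the scatter). Exchanging the three carbons of isopropyl for one chlorine therefore does not separate these two compounds, and this aromatic carbon now has a measured step alongside the earlier one on the nitrogen. No available evidence bears on this result. On these data alone, whether an amine or a carboxylic acid on this aromatic carbon would give a step beyond the scatter remains open. Also open, as far as these compounds go, is whether chloro behaves alike with 3-nitrophenyl on the nitrogen.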